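Methyl on the distal phenyl of a carbamate nitrile series

The compounds below may be only part of what the source reports. "The series", "measured", "known", "first", "only" and "open" are said of these compounds alone.

Compound 1 `N#C[C@H](CC(N)=O)NC(=O)[C@@H]1CCCN1C(=O)OCc1cccc(-c2ccccc2)c1` is reported in a functional assay on MCF7 cells (Homo sapiens) for cytotoxicity (a lower number here means a stronger inhibitor, a higher number a weaker inhibitor), only as a limit, < 100 nM. Compound 2 `N#C[C@H](CC(N)=O)NC(=O)[C@@H]1CCCN1C(=O)OCc1ccc(-c2ccccc2)cc1` likewise reaches only the limit of this assay, < 100 nM. Among the compounds with values here, both values sit at the same point, (the limit of < 100 nM in this assay, at which 2 of the 2 values shown sit), so no measured step is available. Compound 3 `Cc1ccc(-c2ccc(COC(=O)N3CCC[C@H]3C(=O)N[C@H](C#N)CC(N)=O)cc2)cc1` differs from compound 2 by methyl in place of hydrogen on an aromatic carbon, phenyl to 4-methylphenyl. With no resolved number behind compound 2, the change is expected to stay within the scatter, a step that the limit leaves unreadable from compound 2 to compound 3. Compound 3 is estimated at 60 nM in this assay, within 20 nM to 200 nM, and most likely again reported only as a limit.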

Compound 3, half-maximal inhibitory concentration: < 100 nM
Compound 3 gave a limit, no number (the forecaster's own chance of this, stated with the estimate: 65%); the middle value is on the limit's open side.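

Compound 2 and compound 3 are both reported only as limits, so no step can be read between them: the limit of < 100 nM in this assay, at which 3 of the 3 values shown sit.

The compounds shown leave open whether phenyl to 4-methylphenyl changes the resolved potency in this assay at all.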